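A few compounds are considered here, and "the series" means these few. Any claim that something is new, unique, unknown or untested is made for them only; others in the source may bear on it.

Measured so far in an ADME assay on MT4 cells (Homo sapiens) for cytotoxicity, read by MTT assay, with a stated time of 96 h; on this read-out lower numbers stand for higher toxicity in this test and higher numbers for lower toxicity in this test:
compound 1 `CN(CC(=O)O)Cc1c(O)ccc2ccc(=O)oc12`, > 100000 nM
compound 2 `COc1ccc2c(=O)c(Cc3c(OC(C)=O)ccc4c(C)cc(=O)oc34)c(N(C)C)oc2c1`, 42000 nM
compound 3 `CCC(=O)Oc1ccc2ccc(=O)oc2c1Cc1c(-c2ccccc2)[nH]c2ccccc12`, > 100000 nM

The value of compound 3 in this assay is a limit of the assay, not a number. Compound 3 stands at the limit of > 100000 nM in this assay, at which 2 of the 3 values shown sit, together with compound 1, while compound 2 alone gives a number. Compound 4 `CCC(=O)Oc1ccc2c(C)cc(=O)oc2c1Cc1c(-c2ccccc2)[nH]c2ccccc12` differs from compound 3 by methyl in place of hydrogen on an aromatic carbon. No step between measured compounds is known, so nothing shown speaks for movement in either direction; the expected step from compound 3 to compound 4 is a step that the limit leaves unreadable from compound 3 to compound 4, within the scatter. Compound 4 is therefore expected at 120000 nM, in a range from 40000 nM to 300000 nM, most likely reported again as a limit.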

Compound 4, half-maximal cytotoxic concentration: 38000 nM
The estimate for compound 4 lay 3.2-fold (0.50 log units) above the measured number; measured number below the stated range.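

In this assay, methyl in place of hydrogen on an aromatic carbon, opposite the ring oxygen, brings an at least 2.6-fold lower number from compound 3 to compound 4 (0.42 log units; beyond the scatter) with no other change. This position therefore responds to a single added carbon, which compounds 1 to 3 could not show. Compound 3 gives only a limit of the assay, so the step has a lower bound and no exact size: the limit of > 100000 nM in this assay, at which 2 of the 4 values shown sit.

As far as these compounds go, whether ethyl, an amine or a carboxylic acid at this carbon would shift the number further remains open. So does whether methyl here has the same effect with other groups elsewhere on the core.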